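The compounds below may be only part of what the source reports. "The series", "measured", "known", "first", "only" and "open" are said of these compounds alone.

Measured compounds:
- compound 1, `O=C(Nc1ccccc1NC(=O)C(Cl)Cl)C(Cl)Cl`, 131000 nM
- compound 2, `O=C(Nc1cccc(F)c1)C(Cl)Cl`, "not determined" (no result reported)

Among the measured compounds shown here, compound 1 is the only compound of this set with a number in a functional assay on A549 cells (Homo sapiens) for antiproliferative activity, read by MTT assay, with a stated time of 72 h; on this read-out higher numbers stand for weaker inhibition and lower numbers for stronger inhibition; in this assay compound 1 gives 131000 nM, which is a weak result. Compound 2 carries a single dichloroacetamide on a fluoro-substituted benzene, and in this assay compound 2 has no result at all, so it has no standing on the numbers shown. Compound 3, `O=C(Nc1cccc(Br)c1)C(Cl)Cl`, is not yet measured. It differs from compound 2 by bromo in place of fluoro on an aromatic carbon. For the measured compounds named here, no measured pair shows the size of this kind of step, so nothing here says in which direction the change of halogen moves the read-out, and one cannot say whether the step will exceed the scatter. Given that the only number available, that of compound 1, is weak, compound 3 is expected to land in this assay at about 100000 nM, somewhere between 20000 nM and 500000 nM.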

Compound 3, half-maximal inhibitory concentration: 7800 nM
The estimate for compound 3 lay 13-fold (1.11 log units) above the measured number; measured number outside the range, below it.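

Among the compounds shown here, compound 2 has no number in this assay, so no step to compound 3 can be read, although compound 3 gives 7800 nM. The compounds shown leave open how bromo in place of fluoro moves this read-out. Nothing measured here bears on the result.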